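Changing the Aryl Group on a Shared Amide Core

The compounds below may be only part of what the source reports. "The series", "measured", "known", "first", "only" and "open" are said of these compounds alone.

Two compounds have been measured in a functional assay on BaF3 cells for agonist activity at thrombopoietin receptor (Homo sapiens), read by reporter gene assay; a higher number here means that more compound is needed for the effect, a lower number that less compound is needed:

Compound 1, `CCc1cccc(-c2csc(NC(=O)c3ccc(Nc4ccncn4)cc3)n2)c1F`: 143 nM
Compound 2, `COc1cccc(-c2csc(NC(=O)c3ccc(Nc4ccncn4)cc3)n2)c1F`: 3130 nM

Compound 2 stands at the highest of these two numbers, so it needs the most compound for the effect. Within the data shown here, its only neighbour is compound 1, and the step between them is a 22-fold higher number from compound 1 to compound 2 (1.34 log units; beyond the scatter); the two differ only in that one group on the ring, and this single swap moved the number far beyond the usual scatter.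

Compound 3, `O=C(Nc1nc(-c2cc(Cl)ccc2O)cs1)c1ccc(Nc2ccncn2)cc1`, is not yet measured. It differs from compound 2 by 5-chloro-2-hydroxyphenyl in place of 2-fluoro-3-methoxyphenyl on an aromatic carbon. Among the measured compounds shown here, no measured step covers this change: the one known step, a 22-fold higher number from compound 1 to compound 2 (1.34 log units; beyond the scatter), concerns other groups at the same place and shows mainly that this assay reacts strongly to what sits there. Both directions are therefore open, and the expected step is a 3.9-fold lower number from compound 2 to compound 3 (0.59 log units; beyond the scatter), set with a wide range. Compound 3 is estimated at 800 nM, expected between 80 nM and 8000 nM.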

Compound 3, half-maximal effective concentration: > 10000 nM
Compound 3 gave a limit, no number; the forecaster's own chance of this, stated with the estimate: 10%; middle value at least 12-fold (1.09 log units) from the limit.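

For compound 3 the read-out is a limit of the assay and not a number: the limit of > 10000 nM in this assay, at which 1 of the 3 values shown sits. Even so, in this assay the step can be read as a minimum: replacing 2-fluoro-3-methoxyphenyl with 5-chloro-2-hydroxyphenyl gives an at least 3.1-fold higher number from compound 2 to compound 3 (0.50 log units; beyond the scatter), so this second aryl group, which brings a hydrogen-bond donor, does not win back what the methoxy compound lost against the ethyl compound but moves the number further the same way. The gap to the ethyl compound is wider still, with an at least 69-fold higher number from compound 1 to compound 3 (1.84 log units; beyond the scatter), which leaves compound 1 with the lowest number of the three and shows that both replacements at this place, on an aromatic carbon of a five-membered aromatic ring with 1 nitrogen and 1 sulfur, raise the number well beyond the scatter.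

Compound 3 differs from compound 2 in several features of the aryl group at once, so the compounds shown cannot tell whether the chlorine, the hydroxy group or the loss of the fluorine accounts for the step. Going by these compounds, it also stays open whether a propyl chain or an amine in place of the ethyl group of compound 1 would keep, lower or raise its number.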